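Carboxy in Place of a Sulfone: Compound 3 to Compound 4

The compounds below may be only part of what the source reports. "The series", "measured", "known", "first", "only" and "open" are said of these compounds alone.

Compound 1 `O=C(NCCNc1ccc(F)cc1)[C@H](CC1CCCCC1)Nc1nc2cc(F)ccc2o1`: 197 nM
Compound 2 `C[C@@H](CN1CC(C)(C)c2cc(F)ccc21)NC(=O)[C@H](CC1CCCCC1)Nc1nc2cccc(Cl)c2o1`: 3 nM
Compound 3 `CS(=O)(=O)CC[C@@H](CN1CCc2cc(F)ccc21)NC(=O)[C@H](CC1CCCCC1)Nc1nc2ccc(Cl)cc2o1`: 21 nM

These three numbers come from an assay on isolated protein for inhibition of cathepsin S (Homo sapiens); a lower number here means a stronger inhibitor, a higher number a weaker inhibitor. Compound 3 stands second highest of the three: compound 2 sits at a lower number, beyond the scatter, and compound 1 at a higher number, also beyond the scatter. Compound 4 `O=C(O)C[C@@H](CN1CCc2cc(F)ccc21)NC(=O)[C@H](CC1CCCCC1)Nc1nc2ccc(Cl)cc2o1` is not yet measured in this assay. It differs from compound 3 in one place: carboxy in place of (methylsulfonyl)methyl on a saturated chain carbon, two bonds along the chain from an amide-type nitrogen. Among the compounds with values here, no measured pair shows this same change, so the direction is open. The step from compound 3 to compound 4 is expected to be modest, a 1.4-fold higher number from compound 3 to compound 4 (0.15 log units; within the scatter), with neither direction strongly favoured. For compound 4 the estimate in this assay is 30 nM, with a range from 8 nM to 120 nM.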

Compound 4, inhibition constant: 27 nM
For compound 4 the middle estimate is 1.1-fold (0.05 log units) above the measured one; measured number inside the range.
By their numbers in this assay, from the lowest: compound 2; then compounds 3 and 4 (each within the scatter of the next); then compound 1.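

In this assay, putting carboxy in place of (methylsulfonyl)methyl on this saturated chain carbon gives a 1.3-fold higher number from compound 3 to compound 4 (0.11 log units; within the scatter) and so leaves no readable difference between the two groups at this position. Within the data shown here, the earlier compounds offered no pair differing only here, so this step is the only direct reading of the position. Nothing in hand offers an explanation for this result. Going by these compounds, it remains open whether a primary amide, an amine or a longer chain such as carboxyethyl on this carbon would also give a number within the scatter of these two. On these data alone, it is equally open whether the same change would read alike on a different core or aryl substituent pattern.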